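The source may report more compounds than this note shows. Statements on the series, on what has been measured and on what is new or still open speak of the compounds shown alone.

Of the compounds shown here, two built on the shared core have been tested in a functional assay on Malme-3M cells (Homo sapiens) for cytotoxicity, read by sulforhodamine B assay, with a stated time of 48 h, tested at 0.01 uM; on this read-out lower numbers stand for a stronger effect and higher numbers for a weaker effect at the one concentration tested. Compound 1 `COc1ccc(-c2cc(/C=C/C(=O)c3ccc(N)cc3)[nH]n2)cc1` gives 93% and compound 2 `COc1cc(-c2cc(/C=C/C(=O)c3ccc(Cl)c(Cl)c3)[nH]n2)cc(OC)c1OC` gives 94%; the two numbers lie within the scatter of each other. Compound 3 `COc1ccc(-c2cc(/C=C/C(=O)c3ccc(N)cc3)[nH]n2)cc1OC` has not yet been measured. It differs from compound 1 by methoxy in place of hydrogen on an aromatic carbon. Within the data shown here, no measured pair differing in one place is available to size this step. Because compound 1 gives 93% and compound 2 sits within the scatter of it, the step of no change at the digits printed from compound 1 to compound 3 (within the scatter) is expected to stay within the scatter. The estimate for compound 3 in this assay is 93%, ranging from 82% to 104%.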

Compound 3, a percentage reported as activity, at one concentration (the size of the read-out at that concentration, not a potency): 104%
Compound 3: the middle estimate sits 11 percentage points below what was measured; the range from low to high includes it.
By their numbers in this assay, from the lowest: compounds 1, 2 and 3 (each within the scatter of the next, the first and the last beyond it).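

In this assay, among these compounds, methoxy in place of hydrogen on an aromatic carbon, ortho to a methoxy group and meta to a large group, gives the first step that can be sized on this core: a number a number 11 percentage points higher from compound 1 to compound 3 (beyond the scatter), which on this read-out means a modestly weaker effect. This position therefore responds to change, even at the one concentration tested. Nothing shown here explains the shift.

As far as these compounds go, whether fluorine, a methyl group or a hydroxyl group at this position would move the number in the same way remains open. So does whether the step holds at other concentrations.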